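A second trifluoromethyl on compound 3

The source may hold more compounds than are shown below. What is called first, only, known or untested is meant among the compounds shown, and "the series" means these compounds.

In a functional assay on K562 cells (Homo sapiens) for inhibition, read by MTT assay, with a stated time of 72 h (a higher number here means a weaker inhibitor of growth, a lower number a stronger inhibitor of growth), compound 1 (`Cc1cn(-c2cc(C(=O)Nc3cccc(C#Cc4cccc5[nH]nc(N)c45)c3)cc(C(F)(F)F)c2)cn1`) gives 70 nM, compound 2 (`CN1CCN(c2ccc(C(=O)Nc3cccc(C#Cc4cccc5[nH]nc(N)c45)c3)cc2C(F)(F)F)CC1`) gives 1480 nM and compound 3 (`Nc1n[nH]c2cccc(C#Cc3cccc(C(=O)Nc4cccc(C(F)(F)F)c4)c3)c12`) gives 3470 nM. Compound 3 has the highest number of the three, beyond the scatter from both others. Compound 4 (`Nc1n[nH]c2cccc(C#Cc3cccc(C(=O)Nc4cc(C(F)(F)F)cc(C(F)(F)F)c4)c3)c12`) differs from compound 3 in one place: trifluoromethyl in place of hydrogen on an aromatic carbon. For the measured compounds named here, no measured pair shows this change on its own. Compound 1 and compound 2 both have lower numbers than compound 3, but they differ from it in more than this one place, so they offer only a weak guide. A moderate drop beyond the scatter is expected in this assay, namely a 2.9-fold lower number from compound 3 to compound 4 (0.46 log units; beyond the scatter). For compound 4 the estimated value is 1200 nM, with an expected range of 350 nM to 4000 nM.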

Compound 4, concentration for 50% growth inhibition: 520 nM
Compound 4: the middle estimate sits 2.3-fold (0.36 log units) above what was measured; the measured number falls inside the stated range.
By their numbers in this assay, from the lowest: compound 1; then compound 4; then compound 2; then compound 3.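

In this assay, trifluoromethyl in place of hydrogen on an aromatic carbon, meta to a large group and meta to a trifluoromethyl group, gives a 6.7-fold lower number from compound 3 to compound 4 (0.82 log units; beyond the scatter). For the compounds shown here, this is the only step here that isolates a single change, and it shows that adding this group at this position lowers the number beyond the scatter. Nothing measured here accounts for the step.

On these data alone, whether the step belongs to trifluoromethyl itself remains open, since a chlorine or a methoxy group at this position would be needed to tell. The compounds shown also leave open whether the same change would lower the number with an amine on the ring.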